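Working notes: from compound 1 to compound 3

The compounds below may be only part of what the source reports. "The series", "measured", "known", "first", "only" and "open" are said of these compounds alone.

Going by the values given here, compound 1 `COc1cc(Nc2nc(C(=N)Nc3ccc(N4CCN(C)CC4)cc3)cc3c(-c4ccccc4)n[nH]c23)cc(OC)c1OC` is the only member of this series with a number: in a functional assay on PC-3 cells (Homo sapiens) for cytotoxicity, read by MTT assay, with a stated time of 72 h (on this read-out higher numbers stand for weaker inhibition and lower numbers for stronger inhibition), compound 1 gives 4300 nM. Compound 2 `COc1ccc(Cn2nc(-c3ccccc3)c3cc(C(=N)Nc4cccc(C(F)(F)F)c4)nc(NC4CCCCC4)c32)cc1` carries no result in this assay, as compound 2 shows "not determined" (no result reported), so compound 1 stands alone and cannot be ranked against anything. Compound 3 `COc1cc(Nc2nc(C(=N)Nc3ccccc3)cc3c(-c4ccccc4)n[nH]c23)cc(OC)c1OC` differs from compound 1 by hydrogen in place of 4-methylpiperazin-1-yl on an aromatic carbon. Among the compounds with values here, no step between measured compounds exists to calibrate this change. The removal is expected to give a step of a 1.5-fold higher number from compound 1 to compound 3 (0.18 log units; within the scatter) of modest size towards weaker inhibition, possibly within the scatter. Compound 3 is therefore estimated at 6500 nM, between 2000 nM and 20000 nM.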

Compound 3, half-maximal inhibitory concentration: 5800 nM
For compound 3 the middle estimate is 1.1-fold (0.05 log units) above the measured one, within the range that was stated.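

In this assay, hydrogen in place of 4-methylpiperazin-1-yl gives a 1.3-fold higher number from compound 1 to compound 3 (0.13 log units; within the scatter) on this aromatic carbon, para to a large group. Going by these compounds alone, this is the first reading at this position, and it puts compound 1 and compound 3 within the scatter of each other, so the read-out does not separate the full ring from hydrogen here. No measurement at hand offers an explanation for this result.

Open, going by these compounds, is whether a morpholine ring, a carboxylic acid or a dimethylamino chain on this carbon would leave the read-out equally unchanged. Also open, on these data alone, is whether hydrogen in place of 4-methylpiperazin-1-yl would give a similar step with other groups elsewhere on the shared core.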